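This account rests on a few compounds, and the source may have more. Where it says the series, first, only, none or still open, it means among the compounds named here.

Measured in a physicochemical assay, read by spectrophotometry, with a stated time of 30 min; on this read-out higher numbers stand for weaker inhibition and lower numbers for stronger inhibition:
- compound 1 `O=C(CC(c1ccccc1)c1c[nH]c2ccccc12)c1c(O)c2ccccc2oc1=O`: 12.4 ug/mL
- compound 2 `O=C(CC(c1c(Cl)cccc1Cl)c1c[nH]c2ccccc12)c1c(O)c2ccccc2oc1=O`: 13.5 ug/mL
- compound 3 `O=C(CC(c1ccc(F)cc1)c1c[nH]c2ccccc12)c1c(O)c2ccccc2oc1=O`: 47.4 ug/mL

Compound 3 has the highest number of the three, which makes it the weakest inhibitor so far. Compound 4 `COc1ccc(C(CC(=O)c2c(O)c3ccccc3oc2=O)c2c[nH]c3ccccc23)c(OC)c1` keeps the shared core and changes one group: 2,4-dimethoxyphenyl in place of 4-fluorophenyl on a saturated chain carbon bound to an aromatic carbon and a saturated chain carbon.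

Within the data shown here, three measured steps bear on this change. The first is a 3.8-fold higher number from compound 1 to compound 3 (0.58 log units; beyond the scatter), and the second is a 3.5-fold higher number from compound 2 to compound 3 (0.55 log units; beyond the scatter). Both are modest, and both end at compound 3. The third is a 1.1-fold higher number from compound 1 to compound 2 (0.04 log units; within the scatter), so two quite different groups at this place gave numbers that cannot be told apart. Compound 4 has no 4-fluorophenyl group, so it may sit closer to compound 1 and compound 2 than to compound 3. Three compounds make a thin basis, and none of them carries a methoxy group.

In this assay, the expected result is a modest move to a lower number, estimated as a 2.2-fold lower number from compound 3 to compound 4 (0.33 log units; beyond the scatter). The estimate for compound 4 is 22 ug/mL, with an expected range from 9 ug/mL to 55 ug/mL.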

Compound 4, half-maximal inhibitory concentration: 13.2 ug/mL
For compound 4 the middle estimate is 1.7-fold (0.22 log units) above the measured one, within the range that was stated.
By their numbers in this assay, from the lowest: compounds 1, 4 and 2 (each within the scatter of the next); then compound 3.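

In this assay, 2,4-dimethoxyphenyl in place of 4-fluorophenyl on this saturated chain carbon gives a 3.6-fold lower number from compound 3 to compound 4 (0.56 log units; beyond the scatter) and so shows that a substituted ring here need not bring the weaker inhibition of compound 3. The other two steps, a 1.0-fold lower number from compound 2 to compound 4 (0.01 log units; within the scatter) and a 1.1-fold higher number from compound 1 to compound 4 (0.03 log units; within the scatter), are within the scatter, so phenyl, 2,6-dichlorophenyl and 2,4-dimethoxyphenyl cannot be told apart, and compound 3 alone stands out as the weakest of the four. Nothing measured here explains why 4-fluorophenyl differs from the other groups.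

The compounds shown leave open whether 4-methoxyphenyl, with a single methoxy group, would match 2,4-dimethoxyphenyl or 4-fluorophenyl. They also leave open what an amine or a carboxylic acid would do at this place.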